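Swapping chloro for bromo on a fused ring inhibitor

The source may report more compounds than this note shows. Statements on the series, on what has been measured and on what is new or still open speak of the compounds shown alone.

Measured so far:
- Compound 1 `Cc1ccn2nc(S(=O)(=O)Nc3c(F)ccc4cccnc34)nc2n1`: 17.1 nM
- Compound 2 `Cc1ccn2nc(S(=O)(=O)Nc3c(Cl)ccc4cccnc34)nc2n1`: 37.2 nM
- Compound 3 `Cc1cc(C)n2nc(S(=O)(=O)Nc3c(Br)ccc4cccnc34)nc2n1`: 8.7 nM

Of the compounds shown here, three share a common core and have been tested in an assay for inhibition of acetolactate synthase (Nicotiana tabacum); a higher number here means a weaker inhibitor, a lower number a stronger inhibitor. Compound 2 gives the highest number of the three, so it is the weakest inhibitor here; compound 1 sits closest to it, and compound 3 furthest away. For the measured compounds named here, the one clean comparison among them is the step of a 2.2-fold higher number from compound 1 to compound 2 (0.34 log units; beyond the scatter), a change of chloro in place of fluoro on an aromatic carbon.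

The next compound, compound 4 `Cc1ccn2nc(S(=O)(=O)Nc3c(Br)ccc4cccnc34)nc2n1`, differs from compound 2 in one place: bromo in place of chloro on an aromatic carbon. Going by the values given here, no measured pair shows exactly this change. Compound 3 also carries bromo and gives 8.7 nM, but it differs from compound 2 in more than one place, so its value can only hint at the direction. The measured step from fluoro to chloro was modest and toward weaker inhibition, while compound 3 points toward stronger inhibition for a bromo-bearing compound.

Taken together, compound 4 is expected to land close to compound 2, with the step of a 1.2-fold lower number from compound 2 to compound 4 (0.09 log units; within the scatter) estimated to stay near the scatter. Compound 4 is therefore estimated at 30 nM, within a range from 10 nM to 90 nM.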

Compound 4, half-maximal inhibitory concentration: 19.2 nM
Compound 4: the middle estimate sits 1.6-fold (0.19 log units) above what was measured; the range from low to high includes it.
By their numbers in this assay, from the lowest: compounds 3, 1, 4 and 2 (each within the scatter of the next, the first and the last beyond it).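

In this assay, the halogen change at this position is small: a 1.9-fold lower number from compound 2 to compound 4 (0.29 log units; within the scatter) and a 1.1-fold higher number from compound 1 to compound 4 (0.05 log units; within the scatter) both stay within the usual scatter, so compound 4 cannot be told apart from either neighbour, even though a 2.2-fold higher number from compound 1 to compound 2 (0.34 log units; beyond the scatter) does separate those two. For the compounds shown here, the clearer difference in this set lies elsewhere on the shared core, where the single change of hydrogen in place of methyl on an aromatic carbon gives a 2.2-fold higher number from compound 3 to compound 4 (0.34 log units; beyond the scatter), so the low number of compound 3 comes with its extra methyl and not with bromo alone. Nothing available here explains either the small halogen differences or the methyl step.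

From the compounds shown here alone, it remains open whether a different group at the halogen position, such as a methoxy group or a nitrile, would give a number outside the narrow band seen for fluoro, chloro and bromo. Going by these compounds, it is also open whether the extra methyl would shift the fluoro and chloro compounds as it does the bromo compound.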